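Hydroperoxide to alcohol on a triterpenoid side chain

This account rests on a few compounds, and the source may have more. Where it says the series, first, only, none or still open, it means among the compounds named here.

Compound 1 `CC1=CC[C@H]2[C@H](CC[C@]2(C)O)C(C)(C)[C@@H]1CC[C@H]1[C@]2(C)CC[C@H](OCc3ccccc3)C(C)(C)O[C@H]2CC[C@@]1(C)O`: in a functional assay on MCF7 cells (Homo sapiens) for antiproliferative activity, read by MTT assay, with a stated time of 72 h (on this read-out higher numbers stand for weaker inhibition and lower numbers for stronger inhibition), compound 1 gives only a limit, > 50000 nM.
Compound 2 `CC1=CC[C@H]2[C@H](CC[C@]2(C)O)C(C)(C)[C@@H]1CC[C@H]1[C@]2(C)CC[C@H](OC(=O)c3cccc(C(F)(F)F)c3)C(C)(C)O[C@H]2CC[C@@]1(C)O`: compound 2 gives 37900 nM.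
Compound 3 `C=C(C)C(CC[C@@]1(C)C(CC[C@H]2[C@]3(C)CC[C@H](O)C(C)(C)O[C@H]3CC[C@@]2(C)O)=C(C)CC[C@H]1O)OO`: compound 3 gives 31200 nM.

Compound 3 and compound 2 give numbers within the usual scatter of each other, and compound 1 reached only the limit (the limit of > 50000 nM in this assay, at which 1 of the 3 values shown sits). Compound 4 `CC1=C(CC[C@H]2[C@]3(C)CC[C@H](O)C(C)(C)O[C@H]3CC[C@@]2(C)O)[C@](C)(C/C=C/C(C)(C)O)[C@H](O)CC1` differs from compound 3 by a group of 6 heavy atoms (5 carbon, 1 oxygen; no ring) in place of a group of 7 heavy atoms (5 carbon, 2 oxygen; no ring), on a saturated chain carbon bound to a saturated ring carbon. Among the compounds with values here, the only measured step, an at least 1.3-fold lower number from compound 1 to compound 2 (0.12 log units; that floor lies within the scatter), concerns a different position and stays within the scatter, so no measured step tests the present change. Compound 4 is therefore expected to give 31200 nM, between 12000 nM and 80000 nM. The step of no change at the digits printed from compound 3 to compound 4 (within the scatter) is thus estimated to stay within the scatter.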

Compound 4, half-maximal inhibitory concentration: 21800 nM
Compound 4: the middle estimate sits 1.4-fold (0.16 log units) above what was measured; measured number inside the range.
By their numbers in this assay, from the lowest: compounds 4, 3 and 2 (each within the scatter of the next). At a limit, above all of these: compound 1.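

In this assay, within the data shown here, the change on the saturated chain carbon bound to a saturated ring carbon gives a 1.4-fold lower number from compound 3 to compound 4 (0.16 log units; within the scatter), the first measured step at this position. The hydroperoxide of compound 3 is thus not needed for the antiproliferative effect seen here, since the alcohol of compound 4, carried on 3-hydroxy-3-methylbut-1-en-1-yl, reads the same within the scatter. Nothing measured here bears on why the two compounds match. On these data alone, whether an amine or a carboxylic acid in this place would move the number beyond the scatter stays open.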